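From benzamido to 3-aminopropyl: notes on the series

This account rests on a few compounds, and the source may have more. Where it says the series, first, only, none or still open, it means among the compounds named here.

In a functional assay on HT-29 cells (Homo sapiens) for cytotoxicity, read by MTT assay, with a stated time of 72 h (on this read-out higher numbers stand for weaker inhibition and lower numbers for stronger inhibition), the measured compounds read as follows:
- compound 1 `Nc1cccc(Nc2c(C(=O)NCc3ccc(F)cc3)nc(Br)c3cccnc23)c1` gives > 10000 nM as a limit
- compound 2 `CC(C)(C)OC(=O)N1CCN(c2c(C(=O)NCc3ccc(F)cc3)nc(Br)c3cccnc23)CC1` gives > 10000 nM as a limit
- compound 3 `O=C(NCCCNc1c(C(=O)NCc2ccc(F)cc2)nc(Br)c2cccnc12)c1ccccc1` gives > 10000 nM as a limit

For compound 3 the reading > 10000 nM is a limit and not a number. For the measured compounds named here, the set offers no other position to compare it with, since the only reading so far is the limit of > 10000 nM in this assay, at which 3 of the 3 values shown sit, and no compound has yet given a number.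

Compound 4 `NCCCCCCNc1c(C(=O)NCc2ccc(F)cc2)nc(Br)c2cccnc12` carries 3-aminopropyl in place of benzamido on a saturated chain carbon, three bonds along the chain from a nitrogen on an aromatic ring and the rest of the structure stays the same. Cut one bond further out, the same difference reads 2-benzamidoethyl to 5-aminopentyl.

Going by the values given here, no measured step gives a size to lean on. In this assay the expected change is small and toward stronger inhibition, and the estimate an at least 1.2-fold lower number from compound 3 to compound 4 (0.09 log units; that floor lies within the scatter) may not clear the usual scatter. A reading at the same limit would be no surprise.

Compound 4 is expected at 8000 nM with an estimated range of 2500 nM to 25000 nM in this read-out.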

Compound 4, half-maximal inhibitory concentration: 5000 nM
For compound 4 the middle estimate is 1.6-fold (0.20 log units) above the measured one; measured number inside the range.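

In this assay compound 4 is the only one of the set to read as a number, while the others stay at a limit: the limit of > 10000 nM in this assay, at which 3 of the 4 values shown sit.

With 3-aminopropyl in place of benzamido on a saturated chain carbon, three bonds along the chain from a nitrogen on an aromatic ring, the series shows an at least 2.0-fold lower number from compound 3 to compound 4 (0.30 log units; that floor lies within the scatter), and with 6-aminohexyl in place of 3-aminophenyl on a nitrogen on an aromatic ring it shows an at least 2.0-fold lower number from compound 1 to compound 4 (0.30 log units; that floor lies within the scatter). Both steps start from a limit, so each gives only a floor, and how far either reaches stays unfixed; what the series gains is a first number, reached with a chain ending in a free amine on the shared core.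

A single number gives no trend with chain length, so a shorter or longer aminoalkyl chain could read either way. From the compounds shown here alone, whether the end amine itself matters stays open too, and a hydroxyl or a carboxylic acid at the end of the same chain would address that question.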